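Replacing bromo by hydroxy on the carbonyl-side ring

The compounds below may be only part of what the source reports. "The series", "measured", "known", "first", "only" and "open" are said of these compounds alone.

Of the compounds shown here, three have been measured in a functional assay on ZR-75-1 cells (Homo sapiens) for cytotoxicity, read by MTT assay, with a stated time of 68 h; a lower number here means a stronger inhibitor, a higher number a weaker inhibitor. Compound 1 `O=C(/C=C/c1cccc(OCc2ccccc2)c1)c1ccccc1Br` gives 2900 nM, compound 2 `O=C(/C=C/c1cccc(OCc2ccccc2)c1)c1ccc(Br)cc1` gives 6500 nM, and compound 3 `O=C(/C=C/c1cccc(OCc2ccccc2)c1)c1ccccc1` gives 8500 nM. Among these, compound 2 holds the second highest number: its nearest neighbour is compound 3, with a 1.3-fold higher number from compound 2 to compound 3 (0.12 log units; within the scatter), a gap within the scatter, and its furthest is compound 1, with a 2.2-fold higher number from compound 1 to compound 2 (0.35 log units; beyond the scatter).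

Compound 4 `O=C(/C=C/c1cccc(OCc2ccccc2)c1)c1ccc(O)cc1` is not yet measured. It differs from compound 2 as follows: hydroxy in place of bromo on an aromatic carbon. Among the compounds with values here, the only measured step at the same place is the one that removes the bromo entirely, a 1.3-fold higher number from compound 2 to compound 3 (0.12 log units; within the scatter), which stays within the scatter. Within the data shown here, no measured step introduces a hydroxy anywhere in the core, so the effect of the entering group is unknown from these data. On this basis the change is expected to give no step beyond the scatter, with the estimate leaning slightly toward a higher number as the bromo leaves, in line with compound 3 at 8500 nM. Compound 4 is therefore estimated at 7500 nM, with a range of 3500 nM to 16000 nM, which corresponds to an expected step of a 1.2-fold higher number from compound 2 to compound 4 (0.06 log units; within the scatter).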

Compound 4, half-maximal inhibitory concentration: 4900 nM
Beside the measured number, compound 4's estimate is 1.5-fold (0.18 log units) above it; low and high end bracket the measured number.
By their numbers in this assay, from the lowest: compounds 1, 4, 2 and 3 (each within the scatter of the next, the first and the last beyond it).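

In this assay, within the data shown here, a hydroxy, the first group with a hydrogen-bond donor at this position, stays within the scatter of both the bromo (a 1.3-fold lower number from compound 2 to compound 4 (0.12 log units; within the scatter)) and the bare hydrogen (a 1.7-fold lower number from compound 3 to compound 4 (0.24 log units; within the scatter)). The comparison with the 2-bromophenyl compound (a 1.7-fold higher number from compound 1 to compound 4 (0.23 log units; within the scatter)) is also within the scatter, so compound 4 is separated from none of the three, although compound 1 and compound 3 are separated from each other. Nothing available here gives a reason for this result.

Open, as far as these compounds go, is whether an amine, a methoxy or a carboxylic acid in place of the hydroxy at this position would also stay within the scatter of compound 2. Also open, from the compounds shown here alone, is how a hydroxy would behave in the place held by the bromo of compound 1.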